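The source may hold more compounds than are shown below. What is called first, only, known or untested is meant among the compounds shown, and "the series" means these compounds.

In an assay on isolated protein for inhibition of Amine oxidase [flavin-containing] B (Homo sapiens), read by fluorescence and spectrophotometry, with a stated time of 20 min (on this read-out lower numbers stand for stronger inhibition and higher numbers for weaker inhibition), compound 1 `N#Cc1cc2cc(-c3ccccc3)n(O)c2cc1C#N` gives 10300 nM. Compound 2 `Cc1ccc(-c2cc3cc(C#N)c(C#N)cc3n2O)cc1` carries methyl in place of hydrogen on an aromatic carbon, and in this assay compound 2 gives 821 nM, so this change made a 13-fold lower number from compound 1 to compound 2 (1.10 log units; beyond the scatter). Compound 3 `COn1c(-c2ccccc2)c(CO)c2cc(C#N)c(C#N)cc21` is built on another core; how the two cores differ is not broken down here. In this assay compound 3 sits at > 100000 nM, which is a limit of the assay rather than a number. Compound 4 `COn1c(-c2ccc(C)cc2)c(CO)c2cc(C#N)c(C#N)cc21` is compound 3 with the same change, (methyl in place of hydrogen on an aromatic carbon). Going by the values given here, compound 4 is expected to show an at least 2.0-fold lower number from compound 3 to compound 4 (0.30 log units; that floor lies within the scatter), set beside a 13-fold lower number from compound 1 to compound 2 (1.10 log units; beyond the scatter) as the only measured example of this change. That expectation rests on one pair alone and starts from the limit of > 100000 nM in this assay, at which 1 of the 3 values shown sits, so the true starting point of compound 3 is not known. In this assay compound 4 is estimated at 50000 nM, somewhere from 8000 nM to 300000 nM.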

Compound 4, half-maximal inhibitory concentration: > 100000 nM
Compound 4: a limit, no number (the forecaster's own chance of this, stated with the estimate: 50%); at least 2.0-fold (0.30 log units) between middle value and limit.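

Going by these compounds alone, compound 3 and compound 4 both sit at a limit in this assay, so no step between them can be read: the limit of > 100000 nM in this assay, at which 2 of the 4 values shown sit.
The compounds shown leave open whether phenyl to 4-methylphenyl changes inhibition at all on the core of compound 3.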